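The source may report more compounds than this note shows. Statements on the series, on what has been measured and on what is new or still open speak of the compounds shown alone.

Measured so far:
compound 1 `CCNc1cc(-c2ccc(NC(=O)Nc3cccc(Cl)c3)cc2C)ccn1` gives 82.7% in an assay on isolated protein for inhibition of serine/threonine-protein kinase PLK1 (Homo sapiens), read by radiometric assay and 33P incorporation, with a stated time of 40 min, tested at 20 uM, in the presence of a further agent that is not named here; a higher number here means more inhibition at the concentration tested (going by the name of the read-out), a lower number less inhibition
compound 2 `CCNc1cc(-c2ccc(NC(=O)Nc3ccc(OC)cc3)cc2C)ccn1` gives 45.8% in this assay
compound 3 `CCNc1cc(-c2ccc(NC(=O)Nc3cccc4ccccc34)cc2C)ccn1` gives 35.3% in this assay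

Compound 3 stands lowest of the three: the steps of a number 47.4 percentage points lower from compound 1 to compound 3 (beyond the scatter) and a number 10.5 percentage points lower from compound 2 to compound 3 (beyond the scatter) both run downward to it, beyond the scatter. Compound 4 `CCNc1cc(-c2ccc(NC(=O)Nc3c(C)cccc3C)cc2C)ccn1` differs from compound 3 by 2,6-dimethylphenyl in place of naphthalen-1-yl on an amide-type nitrogen.

All three measured steps change the group on this same amide-type nitrogen: a number 36.9 percentage points lower from compound 1 to compound 2 (beyond the scatter) and a number 47.4 percentage points lower from compound 1 to compound 3 (beyond the scatter) are large, a number 10.5 percentage points lower from compound 2 to compound 3 (beyond the scatter) is modest. None of them involves 2,6-dimethylphenyl, so the direction for compound 4 is only loosely bounded. The readings for compound 2 and compound 3 suggest a single ring here lands in the middle range, so a modest rise from compound 3 is expected, a number 9.7 percentage points higher from compound 3 to compound 4 (within the scatter). Compound 4 is estimated at 45%, expected between 20% and 70%.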

Compound 4, a percentage reported as inhibition, at one concentration (the size of the read-out at that concentration, not a potency): 42.1%
For compound 4 the middle estimate is 2.9 percentage points above the measured one; the measured number falls inside the stated range.
By their numbers in this assay, from the lowest: compounds 3, 4 and 2 (each within the scatter of the next, the first and the last beyond it); then compound 1.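

In this assay, 2,6-dimethylphenyl on the amide-type nitrogen cannot be separated from naphthalen-1-yl (a number 6.8 percentage points higher from compound 3 to compound 4 (within the scatter)) or from 4-methoxyphenyl (a number 3.7 percentage points lower from compound 2 to compound 4 (within the scatter)), so compound 4 bridges two groups that are themselves separated beyond the scatter. The 3-chlorophenyl group of compound 1 remains clearly apart from this new group (a number 40.6 percentage points lower from compound 1 to compound 4 (beyond the scatter)). No measurement shown explains these differences.

Open, as far as these compounds go, is whether the reading of compound 1 depends on chlorine itself, which a bromine or a methyl in its place would test. From the compounds shown here alone, an amine or a carboxylic acid on this phenyl ring also remains unexplored here.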